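This account rests on a few compounds, and the source may have more. Where it says the series, first, only, none or still open, it means among the compounds named here.

Compound 3 `FC(F)(F)c1ccc(NC(=S)OCCc2ccccn2)cc1` shares its core with compound 1 `Fc1cccc(NC(=S)OCCc2ccccn2)c1` and compound 2 `S=C(Nc1cccc(Cl)c1)OCCc1ccccn1`. In an ADME assay on MT4 cells (Homo sapiens) for cytotoxicity, read by MTT assay (on this read-out lower numbers stand for higher toxicity in this test and higher numbers for lower toxicity in this test), compound 3 gives 50000 nM, the highest of the two numbers read in this set. Its nearest neighbour is compound 2, which gives 47000 nM in this assay, a difference within the scatter. Compound 1 gives >= 100000 nM in this assay, and this is a limit of the measurement rather than a number.

Compound 4 `O=[N+]([O-])c1ccc(NC(=S)OCCc2ccccn2)cc1` differs from compound 3 in one place: nitro in place of trifluoromethyl on an aromatic carbon. Among the compounds with values here, the only step measured between two compounds that differ in one place is an at least 2.1-fold lower number from compound 1 to compound 2 (0.32 log units; beyond the scatter), an exchange of one halogen for another; no measured step concerns a nitro group or a trifluoromethyl group, so there is no direct guide to this change. Compound 4 is therefore expected to sit close to compound 3 in this assay. The expected step is no change at the digits printed from compound 3 to compound 4 (within the scatter), not beyond the scatter. The estimated value for compound 4 in this assay is 50000 nM, with a range from 20000 nM to 100000 nM.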

Compound 4, half-maximal cytotoxic concentration: > 100000 nM
Compound 4: no number, only a limit; the forecaster's own chance of this, stated with the estimate: 25%; middle value at least 2.0-fold (0.30 log units) away from the limit.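

In this assay, nitro in place of trifluoromethyl, on an aromatic carbon para to a large group, gives an at least 2.0-fold higher number from compound 3 to compound 4 (0.30 log units; that floor lies within the scatter). Compound 4 gives > 100000 nM, which is a limit of the assay and not a number. The earlier compounds offered no step at this position, and this one adds only a floor that cannot be told apart from the scatter, so it shows that the exchange brings no fall in the number but not how large any rise may be, with the reading resting on a limit: the limit of > 100000 nM in this assay, at which 1 of the 4 values shown sits.

The compounds shown leave open how far the true value of compound 4 lies from that limit. They also leave open whether an amine or a carboxylic acid at this position would read like nitro or like trifluoromethyl.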